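This account rests on a few compounds, and the source may have more. Where it says the series, first, only, none or still open, it means among the compounds named here.

Measured so far in an ADME assay on the whole organism (Mus musculus, strain C57BL6/N) for pharmacokinetics, read by LC-MS, with a stated time of 24 h, at a dose of 50 mg/kg by the oral route (on this read-out higher numbers stand for higher oral bioavailability and lower numbers for lower oral bioavailability), are these compounds:
compound 1 `C[C@@H]1Cc2cc(C(N)=O)cnc2N1` gives 220%
compound 2 `NC(=O)c1cnc2c(c1)CCN2` gives 223%

For the measured compounds named here, compound 1 has only one neighbour on these numbers, and the measured step is a number 3 percentage points higher from compound 1 to compound 2 (within the scatter) with hydrogen in place of methyl on a saturated ring carbon. Compound 3 `Cc1c(C(N)=O)cnc2c1C[C@@H](C)N2` is not yet measured. Its difference from compound 1 is methyl in place of hydrogen on an aromatic carbon in words methyl in place of hydrogen on an aromatic carbon, ortho to a carbamoyl group. Going by the values given here, no measured step sits on an aromatic carbon. Among the compounds with values here, the only guide is the methyl step on the saturated ring carbon, which stayed within the scatter, so no step beyond the scatter is expected in this assay in either direction. The expected step is a number 5 percentage points lower from compound 1 to compound 3 (within the scatter) with wide margins. For compound 3 the estimated value is 215% with an expected range from 160% to 260% in this read-out.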

Compound 3, oral bioavailability: 129%
Beside the measured number, compound 3's estimate is 86 percentage points above it; the whole stated range lies above it.
By their numbers in this assay, from the lowest: compound 3; then compounds 1 and 2 (each within the scatter of the next).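

In this assay the aromatic carbon ortho to a carbamoyl group proves sensitive to a small change: methyl in place of hydrogen there gives a number 91 percentage points lower from compound 1 to compound 3 (beyond the scatter) in the core of compound 1. For the compounds shown here, the only earlier step, on a saturated ring carbon, gives a number 3 percentage points higher from compound 1 to compound 2 (within the scatter) and so showed no such sensitivity, which means that the effect of a methyl group depends on where it sits. Nothing available bears on the reason for the drop.

Going by these compounds, it remains open whether a different group on this aromatic carbon, such as chlorine, an amine or a longer chain, would lower the number as far as methyl does. On these data alone, it is also open whether the same methyl change would have a similar effect on compound 2, which lacks the methyl on the saturated ring carbon.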